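The source may hold more compounds than are shown below. What is called first, only, known or untested is meant among the compounds shown, and "the series" means these compounds.

Compound 3 is `Nc1cc(N)c2nc(-c3ccccc3)c(Oc3ccc(F)cc3)nc2c1`. Within the data shown here, in a functional assay on Hs-578T cells (Homo sapiens) for inhibition, read by sulforhodamine B assay, with a stated time of 48 h (a higher number here means a weaker inhibitor of growth, a lower number a stronger inhibitor of growth), compound 3 gives 53700 nM, and this is the only actual number in the set so far. Compound 1 is `Nc1cc(N)c2nc(-c3ccccc3)c(NCc3ccc(F)cc3)nc2c1` and compound 2 is `COc1ccc(Sc2nc3cc(N)cc(N)c3nc2-c2ccccc2)cc1`. For compound 1 this assay reports a limit, < 100000 nM. For compound 2 this assay likewise reports a limit, < 100000 nM. Both limits sit at the limit of < 100000 nM in this assay, at which 2 of the 3 values shown sit. The three measured steps are therefore not readable in size: a step that the two limits leave unreadable from compound 1 to compound 2, a step that the limit leaves unreadable from compound 1 to compound 3 and a step that the limit leaves unreadable from compound 2 to compound 3.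

Compound 4 is `Nc1cc(N)c2nc(-c3ccccc3)c(Sc3ccc(F)cc3)nc2c1`; it differs from compound 3 by (4-fluorophenyl)sulfanyl in place of 4-fluorophenoxy on an aromatic carbon. Among the measured compounds shown here, the nearest measured comparison is compound 2, whose (4-methoxyphenyl)sulfanyl group also attaches through sulfur, but the limit for compound 2 leaves that step unreadable, so no measured step gives a readable size for the change from oxygen to sulfur at this position. The expectation for compound 4 therefore rests on compound 3 alone and carries wide uncertainty, with a 1.3-fold lower number from compound 3 to compound 4 (0.13 log units; within the scatter) expected as the step and a real chance that this assay again reports only a limit. Compound 4 is estimated at 40000 nM, with a range from 15000 nM to 100000 nM.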

Compound 4, concentration for total growth inhibition: 61700 nM
Estimate against measurement, compound 4: 1.5-fold (0.19 log units) below; the measured number falls inside the stated range.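

Working notes on the series: in this assay, replacing the oxygen link with a sulfur link on the 4-fluorophenyl group gives a 1.1-fold higher number from compound 3 to compound 4 (0.06 log units; within the scatter), the first readable step at this position, on the aromatic carbon next to the ring nitrogen. The leaving and entering groups have the same heavy-atom count and differ only in that linking atom, so for this pair the exchange of oxygen for sulfur does not separate compound 3 from compound 4 in this assay. The steps to compound 4 from compound 1 and from compound 2 cannot be read, since each of those two compounds carries only a limit of the assay: the limit of < 100000 nM in this assay, at which 2 of the 4 values shown sit.

Still open, on these data alone, is whether this flat reading extends to other links at the same position, such as a (4-fluorophenyl)sulfonyl or a (4-fluorophenyl)amino group. Also open, as far as these compounds go, is whether a group other than fluoro on the outer ring, such as a dimethylamino group or a carboxylic acid, would move the number beyond the scatter.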